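The source may report more compounds than this note shows. Statements on the series, on what has been measured and on what is new or still open speak of the compounds shown alone.

Of the compounds shown here, three built on a shared core have been tested in a functional assay on Vero cells (Chlorocebus sabaeus) for cytotoxicity; on this read-out lower numbers stand for higher toxicity in this test and higher numbers for lower toxicity in this test. In this assay compound 1 `CC(C)OC(=O)C(O)Cn1cnc2c(N)ncnc21` gives only a limit, > 400 ug/mL. Compound 2 `Nc1ncnc2c1ncn2CC(O)C(=O)OCc1ccco1` gives 40 ug/mL in this assay. Compound 3 `CC(C)COC(=O)C(O)Cn1cnc2c(N)ncnc21` likewise gives only a limit in this assay, > 400 ug/mL. Two of the three values thus sit at the limit of > 400 ug/mL in this assay, at which 2 of the 3 values shown sit, and compound 3 stands at that limit rather than at a number.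

The next compound, compound 4 `CC(C)(C)OC(=O)C(O)Cn1cnc2c(N)ncnc21`, differs from compound 3 in one place: tert-butyl in place of isobutyl on an oxygen next to a carbonyl group. Of the measured steps, the one closest in kind is a step that the two limits leave unreadable from compound 1 to compound 3; both of its ends are limits, so its size cannot be read. The other two steps are an at least 10-fold lower number from compound 1 to compound 2 (1.00 log units; beyond the scatter) and an at least 10-fold higher number from compound 2 to compound 3 (1.00 log units; beyond the scatter), and each involves the (furan-2-yl)methyl group, which plays no part in the present change. A swap of one branched alkyl group for another on an oxygen next to a carbonyl group therefore has no readable precedent here, and no step beyond the scatter is expected in this assay. For compound 4 the expected value in this assay is 400 ug/mL, with a range from 150 ug/mL to 1200 ug/mL. The step from compound 3 to compound 4 that this estimate means is a number no higher from compound 3 to compound 4 (the limit leaves the size open).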

Compound 4, minimum cytotoxic concentration: > 400 ug/mL
Compound 4: a limit, no number (the forecaster's own chance of this, stated with the estimate: 80%); the middle value lies on the limit itself.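

With tert-butyl on the oxygen next to a carbonyl group, compound 4 gives a limit and not a number, so a third branched alkyl group joins isopropyl and isobutyl at the same limit in this assay: the limit of > 400 ug/mL in this assay, at which 3 of the 4 values shown sit.

Among the compounds shown here, the one new step that can be read is an at least 10-fold higher number from compound 2 to compound 4 (1.00 log units; beyond the scatter), which shows for tert-butyl the same kind of separation from the (furan-2-yl)methyl group that isobutyl showed in compound 3. Going by these compounds, the steps to compound 4 from compound 1 and from compound 3 join two limits and cannot be read, so isopropyl, isobutyl and tert-butyl cannot be placed in any order, and whether they differ at all in this test stays unknown.

Among these four compounds, only compound 2 gives a number, 40 ug/mL, and it alone carries a ring on this oxygen. On these data alone, whether a benzyl group, or a longer chain such as n-octyl, at this place would also give a number, or would give a limit as the three branched alkyl groups do, remains open.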